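Compound 4: 1-methyl-1H-indol-3-yl for 4-(trifluoromethyl)phenyl

The source may hold more compounds than are shown below. What is called first, only, known or untested is meant among the compounds shown, and "the series" means these compounds.

In a functional assay on MCF7 cells (Homo sapiens) for inhibition, read by CCK-8 assay, with a stated time of 48 h (on this read-out lower numbers stand for stronger inhibition and higher numbers for weaker inhibition), compound 3 `COc1cc(-c2ccnc3cc(-c4ccc(C(F)(F)F)cc4)nn23)cc(OC)c1OC` gives 2440 nM, within the scatter of compound 1 `COc1cc(-c2ccnc3cc(-c4ccc(F)cc4)nn23)cc(OC)c1OC` at 1280 nM, whereas compound 2 `COc1cc(-c2ccnc3cc(-c4ccc5c(ccn5C)c4)nn23)cc(OC)c1OC` gives 3 nM. The next structural change leads to compound 4 `COc1cc(-c2ccnc3cc(-c4cn(C)c5ccccc45)nn23)cc(OC)c1OC`: 1-methyl-1H-indol-3-yl in place of 4-(trifluoromethyl)phenyl on an aromatic carbon, with 1-methyl-1H-indol-3-yl in place of 4-(trifluoromethyl)phenyl on an aromatic carbon. The closest evidence is the large 810-fold higher number from compound 2 to compound 3 (2.91 log units; beyond the scatter), together with the large 430-fold lower number from compound 1 to compound 2 (2.63 log units; beyond the scatter); both involve 1-methyl-1H-indol-5-yl, a different group from that of compound 4. The a 1.9-fold higher number from compound 1 to compound 3 (0.28 log units; within the scatter) stays within the scatter. Only part of the large difference is therefore expected to carry over, towards a lower number. The expected change is a 31-fold lower number from compound 3 to compound 4 (1.48 log units; beyond the scatter). For compound 4 the estimate is 80 nM, with an expected range of 6 nM to 1200 nM.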

Compound 4, half-maximal inhibitory concentration: 95 nM
Estimate against measurement, compound 4: 1.2-fold (0.07 log units) below; low and high end bracket the measured number.
By their numbers in this assay, from the lowest: compound 2; then compound 4; then compounds 1 and 3 (each within the scatter of the next).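

In this assay, 1-methyl-1H-indol-3-yl on this aromatic carbon gives a 26-fold lower number from compound 3 to compound 4 (1.41 log units; beyond the scatter) and a 13-fold lower number from compound 1 to compound 4 (1.13 log units; beyond the scatter), so a large drop in the number is not confined to 1-methyl-1H-indol-5-yl. The point of attachment on the indole also counts, with 1-methyl-1H-indol-3-yl in place of 1-methyl-1H-indol-5-yl giving a 32-fold higher number from compound 2 to compound 4 (1.50 log units; beyond the scatter). No measurement available here explains these differences.

Still open, going by these compounds, is how the number responds when the methyl on the indole nitrogen is replaced by hydrogen or a longer chain. On these data alone, the effect of an amine or a carboxylic acid on the indole is also open.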